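The compounds below may be only part of what the source reports. "The series", "measured", "known", "first", "only" and "open" are said of these compounds alone.

Compound 1 `CCC(C)NC(=C\C(=O)/C=C/c1ccc(O)c(OC)c1)/C=C/c1ccc(O)c(OC)c1`: > 25000 nM (a limit)
Compound 2 `C=CCNC(=C\C(=O)/C=C/c1ccc(O)c(OC)c1)/C=C/c1ccc(O)c(OC)c1`: 7400 nM
Compound 3 `COc1cc(/C=C/C(=O)/C=C(/C=C/c2ccc(O)c(OC)c2)NC2CCCCC2)ccc1O`: not yet measured

Going by the values given here, in a functional assay on CHO-K1 cells (Cricetulus griseus) for inhibition, read by MTT assay, with a stated time of 72 h (on this read-out lower numbers stand for stronger inhibition and higher numbers for weaker inhibition), compound 2 gives the only true number so far, 7400 nM. Compound 1 reaches only a limit, > 25000 nM.

Compound 3 keeps the shared core and changes one group, with cyclohexyl in place of allyl on an amine nitrogen. The incoming group brings one six-membered non-aromatic ring of carbon only, and the double bond of allyl is lost.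

Among the compounds with values here, one measured step bears on this change, at the same kind of amine nitrogen: an at least 3.3-fold lower number from compound 1 to compound 2 (0.52 log units; beyond the scatter). On these data alone, it lies beyond the scatter, but its true size is unknown, since one end is a limit. It is also a single example, so it is only a weak guide.

Given an at least 3.3-fold lower number from compound 1 to compound 2 (0.52 log units; beyond the scatter), the number in this assay is expected to rise, with an estimated 2.0-fold higher number from compound 2 to compound 3 (0.31 log units; beyond the scatter). For compound 3 the expected value is 15000 nM, with an estimated range from 6000 nM to 40000 nM.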

Compound 3, half-maximal inhibitory concentration: 24700 nM
Estimate against measurement, compound 3: 1.6-fold (0.22 log units) below; the range from low to high includes it.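

In this assay, going by these compounds alone, the step at this amine nitrogen now has a true number at both ends, which gives it a definite size for the first time: a 3.3-fold higher number from compound 2 to compound 3 (0.52 log units; beyond the scatter). Of the three groups shown on this nitrogen, allyl gives the lowest number, and replacing it with cyclohexyl weakens inhibition by an amount beyond the usual scatter. The step with cyclohexyl in place of sec-butyl has a limit at one end, so its true size cannot be read: an at least 1.0-fold lower number from compound 1 to compound 3 (0.00 log units; that floor lies within the scatter). Compound 1 stands only at a limit of the assay: the limit of > 25000 nM in this assay, at which 1 of the 3 values shown sits.

Cyclohexyl differs from allyl in several ways at once: it adds a ring, has more carbon atoms and lacks the double bond, and this single step cannot separate these differences. Still open, on these data alone, is how a propyl chain, which has no double bond, or a cyclopropyl ring, which is a much smaller ring than cyclohexyl, would behave on this nitrogen, and whether any group there could bring the number well below that of compound 2.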